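A few compounds are considered here, and "the series" means these few. Any claim that something is new, unique, unknown or untested is made for them only; others in the source may bear on it.

Compound 1 `Cc1ccc(NC2=CC(=O)c3c(nc4n3[C@H]3OC[C@@H](O)[C@H]3OC4)C2=O)cc1C` gives, in a functional assay on HeLa cells (Homo sapiens) for inhibition, read by sulforhodamine B assay (on this read-out higher numbers stand for weaker inhibition and lower numbers for stronger inhibition), a value of 4320 nM. Compound 2 `O=C1C(N2CCCCC2)=CC(=O)c2c1nc1n2[C@H]2OC[C@@H](O)[C@H]2OC1` is recorded in this assay only as a limit, > 16000 nM. The change an at least 3.7-fold higher number from compound 1 to compound 2 (0.56 log units; beyond the scatter) therefore shows an at least modest loss when the arylamino group is exchanged for a saturated ring amine. Compound 3 `O=C1C=C(NCc2ccccc2)C(=O)c2c1nc1n2[C@H]2OC[C@@H](O)[C@H]2OC1` likewise stands at a limit in this assay, > 8000 nM, so for compound 3 no number is known, only that it sits among the weaker members of the three. Compound 4 `O=C1C=C(Nc2ccc(C(F)(F)F)cc2)C(=O)c2c1nc1n2[C@H]2OC[C@@H](O)[C@H]2OC1` differs from compound 3 by 4-(trifluoromethyl)phenyl in place of benzyl on an amine nitrogen. Among the measured compounds shown here, the only measured step that bears on this position is an at least 3.7-fold higher number from compound 1 to compound 2 (0.56 log units; beyond the scatter), which suggests that an aromatic ring directly on the amine nitrogen, as in compound 1 with its 4320 nM, is compatible with measurable inhibition. For the benzyl variant, compound 3, and the piperidinyl variant, compound 2, only limits are recorded. Compound 4 is therefore expected to land near the number of compound 1: the estimate for compound 4 in this assay is 5000 nM, with a range from 1500 nM to 16000 nM. The estimated step of an at least 1.6-fold lower number from compound 3 to compound 4 (0.20 log units; that floor lies within the scatter) is expected to be an improvement, though a limit cannot be excluded.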

Compound 4, half-maximal inhibitory concentration: > 8000 nM
Compound 4 was reported as a limit (the forecaster's own chance of this, stated with the estimate: 35%); middle value at least 1.6-fold (0.20 log units) away from the limit.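

In this assay compound 4 is recorded only as a limit, > 8000 nM. Compound 3 is also a limit, > 8000 nM, so no step can be read between compound 3 and compound 4. The compounds shown leave open whether 4-(trifluoromethyl)phenyl or benzyl on the amine nitrogen gives stronger inhibition.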